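The source may report more compounds than this note shows. Statements on the series, on what has been measured and on what is new or still open speak of the compounds shown alone.

Measured compounds:
- compound 1, `CCC(C)(C)Cc1c[nH]c(CCc2ccc(-c3ccncc3)cc2)n1`: 15 nM
- compound 2, `CCC(C)(C)Cc1c[nH]c(CCc2ccc(-c3csnn3)cc2)n1`: 11 nM
- compound 3, `CCC(C)(C)Cc1c[nH]c(CCc2ccc(-c3cccc(C)n3)cc2)n1`: 19 nM

The three compounds share one core and differ only in the group carried at the far end. In a functional assay on HEK293 cells for agonist activity at Bombesin receptor subtype-3 (Mus musculus), read by luminescence and calcium flux, with a stated time of 10 min (a higher number here means that more compound is needed for the effect, a lower number that less compound is needed), compound 1 gives 15 nM, the second highest of the three numbers, though every gap here is within the scatter: a 1.4-fold lower number from compound 1 to compound 2 (0.13 log units; within the scatter) and a 1.3-fold higher number from compound 1 to compound 3 (0.10 log units; within the scatter). The remaining pair moves by a 1.7-fold higher number from compound 2 to compound 3 (0.24 log units; within the scatter). No ordering among these three can be read from the numbers.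

Compound 4, `CCC(C)(C)Cc1c[nH]c(CCc2ccc(-n3cncn3)cc2)n1`, is not yet measured. Its change from compound 1 is 1H-1,2,4-triazol-1-yl in place of pyridin-4-yl on an aromatic carbon. Among the compounds with values here, the step that bears on it most is the one to compound 2, where another five-membered heteroaryl replaces the same group with a 1.4-fold lower number from compound 1 to compound 2 (0.13 log units; within the scatter). Within the data shown here, no measured step covers a nitrogen-linked ring. On this basis no step beyond the scatter is expected in this assay, and the estimate for compound 4 is 18 nM with a range of 6 nM to 55 nM, a step of a 1.2-fold higher number from compound 1 to compound 4 (0.08 log units; within the scatter) that is expected rather than known.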

Compound 4, half-maximal effective concentration: 12 nM
For compound 4 the middle estimate is 1.5-fold (0.18 log units) above the measured one, and the stated range covers the measured number.
By their numbers in this assay, from the lowest: compounds 2, 4, 1 and 3 (each within the scatter of the next).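

In this assay a ring attached through nitrogen, 1H-1,2,4-triazol-1-yl, takes the place of pyridin-4-yl on the aromatic carbon with no step beyond the scatter (a 1.3-fold lower number from compound 1 to compound 4 (0.10 log units; within the scatter)), so this position now carries more than carbon-linked rings. The other comparisons also stay within the scatter (a 1.6-fold lower number from compound 3 to compound 4 (0.20 log units; within the scatter); a 1.1-fold higher number from compound 2 to compound 4 (0.04 log units; within the scatter)), even though the entering five-membered ring has 3 hetero atoms and the pyridin-4-yl it replaces has 1 hetero atom, and the four compounds remain without an order. No measured evidence is available to explain these close numbers.

Still open, on these data alone, is whether a non-aromatic group at this position, such as an amine or a carboxylic acid, would give a step beyond the scatter. As far as these compounds go, a longer chain between the aromatic ring of carbon only and the far-end ring is also open.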